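Series notes: benzyl at the amide-type nitrogen

This account rests on a few compounds, and the source may have more. Where it says the series, first, only, none or still open, it means among the compounds named here.

Measured in a functional assay on U-937 cells (Homo sapiens), read by cAMP accumulation; a higher number here means that more compound is needed for the effect, a lower number that less compound is needed
- compound 1 `CCc1nn(C2CCCC2)c2c1CCN(c1cccs1)C2=O` gives 1 nM
- compound 2 `CCc1nn(C2CCCC2)c2c1CCN(c1cccnc1)C2=O` gives 17 nM

Of these two numbers, compound 2 holds the higher, and compound 1 is its nearest neighbour. The next structure, compound 3 `CCc1nn(C2CCCC2)c2c1CCN(Cc1ccccc1)C2=O`, has benzyl in place of pyridin-3-yl on an amide-type nitrogen in a ring.

Within the data shown here, only one measured step bears on this change. It sits at the same nitrogen and is large, beyond the scatter: a 17-fold higher number from compound 1 to compound 2 (1.23 log units; beyond the scatter). Among the measured compounds shown here, that step shows that the number can move considerably with the group at this place, but no measured compound carries benzyl, so the direction remains uncertain. A moderate further rise in this assay is expected, with a wide margin.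

The expected step is a 1.8-fold higher number from compound 2 to compound 3 (0.25 log units; within the scatter).

Compound 3 is estimated at 30 nM, with an expected range of 6 nM to 150 nM.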

Compound 3, half-maximal effective concentration: 36 nM
The estimate for compound 3 lay 1.2-fold (0.08 log units) below the measured number; the range from low to high includes it.
By their numbers in this assay, from the lowest: compound 1; then compound 2; then compound 3.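

Benzyl on the amide-type nitrogen in a ring gives the highest number of the three in this assay, with a modest step from pyridin-3-yl (a 2.1-fold higher number from compound 2 to compound 3 (0.33 log units; beyond the scatter)) and a large one from thiophen-2-yl (a 36-fold higher number from compound 1 to compound 3 (1.56 log units; beyond the scatter)). Among these three groups thiophen-2-yl stands lowest, and the aromatic ring of carbon only in benzyl does not bring the number back toward that of compound 1. No measurement on hand accounts for these differences.

Open, going by these compounds, is whether the rise with benzyl follows from its methylene link or from the absence of the pyridine nitrogen; this step changes both at once. Also open, on these data alone, is how phenyl, thiophen-3-yl or the longer 2-phenylethyl would compare at this nitrogen.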